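The source may hold more compounds than are shown below. What is called first, only, known or untested is meant among the compounds shown, and "the series" means these compounds.

Among the compounds with values here, in a functional assay on RPMI-8226 cells (Homo sapiens) for cytotoxicity, read by MTT assay, with a stated time of 48 h (on this read-out lower numbers stand for stronger inhibition and higher numbers for weaker inhibition), compound 1 `Cc1cccc(NN=C2C(Cl)=C(Cl)C(Cl)=C2Cl)c1` gives 2000 nM and compound 2 `Fc1cccc(NN=C2C(Cl)=C(Cl)C(Cl)=C2Cl)c1` gives 500 nM as the lower of the two numbers so far. Compound 3 `COc1cccc(NN=C2C(Cl)=C(Cl)C(Cl)=C2Cl)c1` is still unmeasured and differs from compound 2 by methoxy in place of fluoro on an aromatic carbon with methoxy in place of fluoro on an aromatic carbon, meta to a large group. Only a 4.0-fold lower number from compound 1 to compound 2 (0.60 log units; beyond the scatter) bears on this change, with fluoro in place of methyl on an aromatic carbon, and that step is modest and beyond the scatter. Within the data shown here, compound 1 at 2000 nM is the one measured case without fluoro, so a modest step to a higher number is expected for compound 3 in this assay even though no methoxy compound has a number yet. The expected move is a 2.0-fold higher number from compound 2 to compound 3 (0.30 log units; within the scatter) on this estimate. For compound 3 the estimated value is 1000 nM within an expected range of 350 nM to 3000 nM as a working figure.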

Compound 3, half-maximal inhibitory concentration: > 3000 nM
Compound 3: only a limit was reported; the forecaster's own chance of this, stated with the estimate: 3%; at least 3.0-fold (0.47 log units) between middle value and limit.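

In this assay compound 3 gives only a limit and not a number: > 3000 nM. Methoxy in place of fluoro on this aromatic carbon, meta to a large group, gives an at least 6.0-fold higher number from compound 2 to compound 3 (0.77 log units; beyond the scatter) and so fluoro now stands apart from both methyl and methoxy, with each step to compound 2 printed as beyond the scatter. Methoxy in place of methyl gives an at least 1.5-fold higher number from compound 1 to compound 3 (0.17 log units; that floor lies within the scatter) and so the order of those two groups stays unsettled, while the full size of both steps stays hidden behind the limit: the limit of > 3000 nM in this assay, at which 1 of the 3 values shown sits.

As far as these compounds go, whether chloro, hydroxy or an amine at this place would stay close to fluoro or move towards methoxy remains open. Also open, from the compounds shown here alone, is whether the preference for fluoro over methyl and methoxy holds elsewhere on the same aromatic ring.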